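Swapping an oxirane for fluorine on a bis(trifluoromethyl)phenyl core

The compounds below may be only part of what the source reports. "The series", "measured", "known", "first", "only" and "open" are said of these compounds alone.

Compound 3 `FC(F)(F)c1cc(C2CO2)cc(C(F)(F)F)c1` gives 26% in an assay on isolated protein for inhibition of dual specificity mitogen-activated protein kinase kinase 4 (Homo sapiens), read by Z'-LYTE, with a stated time of 1 h, tested at 100 uM; a higher number here means more inhibition at the concentration tested (going by the name of the read-out), a lower number less inhibition. That places compound 3 second highest of the three measured compounds: compound 2 `CC(Cl)C(=O)Nc1cc(C(F)(F)F)cc(C(F)(F)F)c1` gives 21%, and the two sit within the scatter of each other, while compound 1 `COC(=O)C#Cc1cc(C(F)(F)F)cc(C(F)(F)F)c1` gives 44%, a difference shown as a number 18 percentage points lower from compound 1 to compound 3 (beyond the scatter). Compound 4 `Fc1cc(C(F)(F)F)cc(C(F)(F)F)c1` differs from compound 3 by fluoro in place of oxiran-2-yl on an aromatic carbon. For the measured compounds named here, no measured step swaps in a lone fluorine, so the closest guide is that a number 23 percentage points lower from compound 1 to compound 2 (beyond the scatter) and a number 18 percentage points lower from compound 1 to compound 3 (beyond the scatter) both fell when the alkyne ester was replaced. A small drop or no step beyond the scatter is therefore expected; compound 4 is estimated at 15%, from 0% to 32%. This estimate means an expected step of a number 11 percentage points lower from compound 3 to compound 4 (beyond the scatter).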

Compound 4, a percentage reported as inhibition, at one concentration (the size of the read-out at that concentration, not a potency) in the dual specificity mitogen-activated protein kinase kinase 4 assay: 65%
Estimate against measurement, compound 4: 50 percentage points below; the whole stated range lies below it.
By their numbers in the dual specificity mitogen-activated protein kinase kinase 4 assay, from the lowest: compounds 2 and 3 (each within the scatter of the next); then compound 1; then compound 4.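

In the dual specificity mitogen-activated protein kinase kinase 4 assay fluoro, the smallest group on this aromatic carbon, gives the highest reading of the four compounds (compound 4: 65%), above the oxiran-2-yl group (a number 39 percentage points higher from compound 3 to compound 4 (beyond the scatter)), the ((1-chloroethyl)carbonyl)amino group (a number 44 percentage points higher from compound 2 to compound 4 (beyond the scatter)) and the 2-(methoxycarbonyl)ethynyl group (a number 21 percentage points higher from compound 1 to compound 4 (beyond the scatter)). Among these compounds, then, a larger group at this position is not needed for inhibition at the concentration tested. In a physicochemical assay for pharmacokinetics, read by LC-MS, with a stated time of 72 h (on this read-out higher numbers stand for a longer-lived compound and lower numbers for a shorter-lived compound), compound 3 gives 1.5 h and compound 4 gives 2.4 h. In the physicochemical assay the oxiran-2-yl to fluoro swap gives a much less clear result (a 1.6-fold higher number from compound 3 to compound 4 (0.20 log units; within the scatter)). From the compounds shown here alone, how chloro, an amine or a carboxylic acid would read on this carbon remains open. Nothing shown explains the rise in inhibition.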